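This account rests on a few compounds, and the source may have more. Where it says the series, first, only, none or still open, it means among the compounds named here.

Compound 2 `CCCCCCCCCCCC[C@@H](O)[C@H]1CC[C@H]([C@H](O)CCCCCCCCCCNC(=O)c2ccoc2)O1` carries a long-chain core with a furan-3-yl group on the carbonyl carbon of its amide. In a functional assay on SNB-78 cells (Homo sapiens) for inhibition, read by colorimetric assay and sulforhodamine B assay, with a stated time of 48 h (a lower number here means a stronger inhibitor of growth, a higher number a weaker inhibitor of growth), compound 2 gives 100000 nM. Two close relatives differ from it only at that aromatic group. Compound 1 `CCCCCCCCCCCC[C@@H](O)[C@H]1CC[C@H]([C@H](O)CCCCCCCCCCNC(=O)c2ccco2)O1` bears a furan-2-yl group instead, and in this assay compound 1 gives 100000 nM. Compound 3 `CCCCCCCCCCCC[C@@H](O)[C@H]1CC[C@H]([C@H](O)CCCCCCCCCCNC(=O)c2cncs2)O1` bears a 1,3-thiazol-5-yl group, and in this assay compound 3 gives 100000 nM. The three values sit level: the step of no change at the digits printed from compound 1 to compound 2 (within the scatter) and the step of no change at the digits printed from compound 1 to compound 3 (within the scatter) each show no change, and the step of no change at the digits printed from compound 2 to compound 3 (within the scatter) also shows none. Among the measured compounds shown here, on the numbers so far, compound 2 therefore stands level with compound 1 and compound 3.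

Compound 4 `CCCCCCCCCCCC[C@@H](O)[C@H]1CC[C@H]([C@H](O)CCCCCCCCCCNC(=O)c2ccsc2)O1` is the next variation on the same theme. Its difference from compound 2 is thiophen-3-yl in place of furan-3-yl on a carbonyl carbon. The measured steps that bear on this are the three exchanges of one five-membered aromatic group for another, none of which moved the read-out. Since swapping the aromatic group has so far left growth inhibition flat, no step beyond the scatter is expected in this assay, and the expected step is no change at the digits printed from compound 2 to compound 4 (within the scatter). For compound 4 the estimate in this assay is 100000 nM, with a range from 50000 nM to 200000 nM.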

Compound 4, concentration for 50% growth inhibition: 100000 nM
Compound 4: the middle estimate sits on the measured number at the digits printed; the measured number falls inside the stated range.
By their numbers in this assay, from the lowest: compounds 1, 2, 3 and 4 (each within the scatter of the next).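

Compound 4 adds the cleanest exchange yet at this position: on the carbonyl carbon, the oxygen of furan-3-yl gives way to the sulfur of thiophen-3-yl, while the five-membered aromatic ring, its single hetero atom and the count of heavy atoms all stay the same, and in this assay this gives no change at the digits printed from compound 2 to compound 4 (within the scatter). The two other new comparisons read the same way, with no change at the digits printed from compound 3 to compound 4 (within the scatter) for thiophen-3-yl in place of 1,3-thiazol-5-yl and no change at the digits printed from compound 1 to compound 4 (within the scatter) for thiophen-3-yl in place of furan-2-yl, so four different five-membered aromatic groups now share one printed value, and compound 4 gives 100000 nM. Nothing measured here offers an explanation for this flat read-out.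

Since all four compounds share that value, these data cannot show what would move the number at this position. A phenyl ring, a pyridine ring or a plain hexyl chain on the same carbonyl carbon remains an open question, as does an amine or a carboxylic acid on the aromatic ring.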